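Swapping tert-butyl for a silicon group on the triazole

The source may hold more compounds than are shown below. What is called first, only, known or untested is meant among the compounds shown, and "the series" means these compounds.

Measured so far:
- compound 1 `CC(C)(C)c1cn(C[C@H](O)[C@H]2OC(=O)C(OCc3ccccc3)=C2OCc2ccccc2)nn1`: 13300 nM
- compound 2 `O=C1O/C(=C\Cn2cc(-c3cc(F)cc(F)c3)nn2)C(OCc2ccccc2)=C1OCc1ccccc1`: > 100000 nM
- compound 3 `Cc1ccc(-c2cn(C/C=C3\OC(=O)C(OCc4ccccc4)=C3OCc3ccccc3)nn2)cc1`: > 100000 nM

For the measured compounds named here, in an ADME assay on HFF cells (Homo sapiens) for cytotoxicity, read by MTT assay, with a stated time of 72 h (a higher number here means a weaker inhibitor, a lower number a stronger inhibitor), compound 1 gives 13300 nM, the only number among the three. For compound 2 the result is a limit of the assay, > 100000 nM. For compound 3 the result is also a limit, > 100000 nM. Going by the values given here, the one step between measured compounds, a step that the two limits leave unreadable from compound 2 to compound 3, is unreadable because both ends sit at the limit of > 100000 nM in this assay, at which 2 of the 3 values shown sit, and it concerns an aryl group far from the change studied here.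

Compound 4 `C[Si](C)(C)c1cn(C[C@H](O)[C@H]2OC(=O)C(OCc3ccccc3)=C2OCc2ccccc2)nn1` differs from compound 1 by a group of 4 heavy atoms (3 carbon, 1 silicon; no ring) in place of a group of 4 heavy atoms (4 carbon; no ring), on an aromatic carbon. Among the compounds with values here, no measured step bears on this change, so a step within the usual scatter is expected: compound 4 is estimated at 15000 nM (range 5000 nM to 45000 nM), a step of a 1.1-fold higher number from compound 1 to compound 4 (0.05 log units; within the scatter) that is expected to be small.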

Compound 4, half-maximal inhibitory concentration: 20000 nM
Compound 4: the middle estimate sits 1.3-fold (0.12 log units) below what was measured; measured number inside the range.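

Swapping tert-butyl for the silicon group on this aromatic carbon gives, in this assay, a 1.5-fold higher number from compound 1 to compound 4 (0.18 log units; within the scatter), so this assay does not separate the two groups at this position. The silicon group is thus tolerated here without a change beyond the scatter, on the core of compound 1. No measurement shown gives a reason for this outcome.

Going by these compounds, whether an amine, a carboxylic acid or a longer chain on this aromatic carbon would move the number beyond the scatter stays open. This single pair also cannot show whether the same swap would behave alike on another core.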